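One Saturated Ring for Another on the Aromatic Arm

A few compounds are considered here, and "the series" means these few. Any claim that something is new, unique, unknown or untested is made for them only; others in the source may bear on it.

Compound 1, `O=C(NCc1ccc(N2CCCC2)cc1)Nc1cccc2cnccc12`: 5.3 nM
Compound 2, `O=C(NCc1ccc(N2CCCCCCC2)cc1)Nc1cccc2cnccc12`: 4.7 nM

These two compounds share a common core and differ only in the saturated ring attached to an aromatic carbon. In a functional assay for antagonist activity at transient receptor potential cation channel subfamily V member 1 (Homo sapiens), read by calcium flux (on this read-out lower numbers stand for stronger inhibition and higher numbers for weaker inhibition), compound 1 gives 5.3 nM and compound 2 gives 4.7 nM. The step of a 1.1-fold lower number from compound 1 to compound 2 (0.05 log units; within the scatter) shows that enlarging this ring barely moved the number. Compound 2 has the lowest of the two numbers, but compound 1 sits within the scatter of it, so no order between them can be claimed.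

Compound 3, `CC1CN(c2ccc(CNC(=O)Nc3cccc4cnccc34)cc2)CC(C)O1`, has not yet been measured. It differs from compound 2 in one place: a group of 8 heavy atoms (6 carbon, 1 nitrogen, 1 oxygen; one six-membered non-aromatic ring with 2 hetero atoms) in place of a group of 8 heavy atoms (7 carbon, 1 nitrogen; one eight-membered non-aromatic ring with 1 hetero atom), on an aromatic carbon. Going by the values given here, the one measured step bearing on this change is a 1.1-fold lower number from compound 1 to compound 2 (0.05 log units; within the scatter), which left the number essentially unchanged when the saturated ring was exchanged at the same place. Among the compounds with values here, the entering group differs in kind, not only in size, and no measured step covers that, so the expectation rests on the tolerance seen so far. The expected step from compound 2 to compound 3 is a 1.7-fold higher number from compound 2 to compound 3 (0.23 log units; within the scatter), small and not beyond the scatter. Compound 3 is estimated at 8 nM, with a range from 3 nM to 25 nM.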

Compound 3, half-maximal inhibitory concentration: 258 nM
For compound 3 the middle estimate is 32-fold (1.51 log units) below the measured one; measured number above the stated range.
By their numbers in this assay, from the lowest: compounds 2 and 1 (each within the scatter of the next); then compound 3.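

The tolerance at this aromatic carbon has a limit: pyrrolidin-1-yl and the eight-membered ring stay within the scatter of each other in this assay, yet placing 2,6-dimethylmorpholin-4-yl there gives a 55-fold higher number from compound 2 to compound 3 (1.74 log units; beyond the scatter) and also a 49-fold higher number from compound 1 to compound 3 (1.69 log units; beyond the scatter). Size counted in heavy atoms does not separate these results, since the group leaving compound 2 and the group entering compound 3 hold the same number of heavy atoms, while the entering group differs in ring size, has a ring oxygen and carries methyl groups. Nothing available here explains why this group gives so much higher a number.

The ring size, the ring oxygen and the methyl groups all change together in this step, so the compounds shown cannot say which of them matters. Plain morpholin-4-yl, piperidin-1-yl and 4,4-dimethylpiperidin-1-yl at the same place would pull these features apart and show whether the loss follows the oxygen, the methyl groups or the six-membered ring.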